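The source may report more compounds than this note shows. Statements on the series, on what has been measured and on what is new or still open speak of the compounds shown alone.

Measured compounds in a functional assay on IGROV-1 cells (Homo sapiens); on this read-out lower numbers stand for stronger inhibition of growth and higher numbers for weaker inhibition of growth:

compound 1 `COc1cc(CSc2cc(Cl)c(-c3nnc(-c4ccccc4)s3)cc2S(=O)(=O)NC(=N)NO)cc(OC)c1OC`: 3720 nM
compound 2 `COc1cc(CSc2cc(Cl)c(-c3nc(-c4ccc(Cl)cc4)no3)cc2S(=O)(=O)NC(=N)NO)cc(OC)c1OC`: 3800 nM
compound 3 `N=C(NO)NS(=O)(=O)c1cc(-c2nnc(-c3ccc(Cl)cc3)s2)c(Cl)cc1SCc1ccccc1`: 2570 nM

Compound 1 stands second highest of the three numbers. Its nearest neighbour is compound 2, where the step of a 1.0-fold higher number from compound 1 to compound 2 (0.01 log units; within the scatter) exchanges the whole heteroaryl group and remains within the scatter. Among the compounds with values here, compound 3 carries a 4-chlorophenyl on its thiadiazole but also a different benzylthio group, so no single-point step connects it to compound 1; its value and that of compound 1 lie within the scatter of each other, and nothing more can be read from the pair.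

Compound 4 `COc1cc(CSc2cc(Cl)c(-c3nnc(-c4ccc(Cl)cc4)s3)cc2S(=O)(=O)NC(=N)NO)cc(OC)c1OC` differs from compound 1 by chloro in place of hydrogen on an aromatic carbon. Within the data shown here, no measured step isolates this change: the only step in the set, from compound 1 to compound 2, introduces a chloro together with a change of the heteroaryl ring and gives no movement beyond the scatter. The values of compounds 1, 2 and 3 all sit close together, so a flat outcome is expected for compound 4, with a step of a 1.1-fold lower number from compound 1 to compound 4 (0.05 log units; within the scatter) that is expected not to exceed the scatter. Compound 4 is therefore estimated at 3300 nM, expected within 1500 nM to 7000 nM in this assay.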

Compound 4, concentration for 50% growth inhibition: 58900 nM
Compound 4: the middle estimate sits 18-fold (1.25 log units) below what was measured; the measured number lies above the stated range.
By their numbers in this assay, from the lowest: compounds 3, 1 and 2 (each within the scatter of the next); then compound 4.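

In this assay, chloro in place of hydrogen on an aromatic carbon, para to a large group, turning phenyl into 4-chlorophenyl on the thiadiazole, is a large change rather than a silent one: a 16-fold higher number from compound 1 to compound 4 (1.20 log units; beyond the scatter). The 4-chlorophenyl group alone does not carry this loss, since replacing the thiadiazole-linked arrangement with the 1,2,4-oxadiazole counterpart gives a compound well separated from the new one (a 16-fold higher number from compound 2 to compound 4 (1.19 log units; beyond the scatter)), and the same holds for the phenyl counterpart on the saturated chain carbon bound to a sulfur (a 23-fold higher number from compound 3 to compound 4 (1.36 log units; beyond the scatter)). Among these four compounds, the weak growth inhibition therefore appears only where 3,4,5-trimethoxyphenyl, 5-(4-chlorophenyl)-1,3,4-thiadiazol-2-yl and the shared core occur together, and each single-place departure from compound 4 returns to the group of compounds 1, 2 and 3.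

Nothing available on these compounds bears on why this combination behaves so differently. Still open, going by these compounds, is whether the rise is specific to chloro or would also follow with fluoro or methoxy at this place, and whether hydrogen in place of chloro would move compound 3 at all.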